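The compounds below may be only part of what the source reports. "The series", "measured", "known", "first", "only" and "open" are said of these compounds alone.

Three measured compounds share one core and differ only in the group attached to the amide-type nitrogen in the ring. In a functional assay on HeLa cells (Homo sapiens) for antiproliferative activity, read by MTT assay, with a stated time of 72 h (a higher number here means a weaker inhibitor, a lower number a stronger inhibitor), compound 1 `COc1ncc(-c2ccc3c(c2)N(C2CCCCC2)C(=O)CO3)cc1NS(=O)(=O)c1ccc(F)cc1` gives 6100 nM. Compound 2 `COc1ncc(-c2ccc3c(c2)NC(=O)CO3)cc1NS(=O)(=O)c1ccc(F)cc1`, which carries hydrogen at that position, gives 7110 nM in this assay. Compound 3 `COc1ncc(-c2ccc3c(c2)N(C2CC2)C(=O)CO3)cc1NS(=O)(=O)c1ccc(F)cc1`, which carries cyclopropyl there, gives 6030 nM in this assay. Its number is the lowest of the three, but the gaps to the others are small: a 1.0-fold lower number from compound 1 to compound 3 (0.01 log units; within the scatter) and a 1.2-fold lower number from compound 2 to compound 3 (0.07 log units; within the scatter), and also a 1.2-fold higher number from compound 1 to compound 2 (0.07 log units; within the scatter), all lie within the scatter of the measurement, so no ranking among the three can be read from them.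

Compound 4 `COc1cccc(N2C(=O)COc3ccc(-c4cnc(OC)c(NS(=O)(=O)c5ccc(F)cc5)c4)cc32)c1` has not yet been measured. It differs from compound 3 by 3-methoxyphenyl in place of cyclopropyl on an amide-type nitrogen in a ring. All three measured steps bear on this change, since each swaps the group at the same nitrogen, and none of them moved the number beyond the scatter. The entering group is larger and aromatic, unlike anything tried so far, which widens the uncertainty, but the data give no reason to expect a shift in either direction. Compound 4 is therefore expected to give about 6000 nM in this assay, with a range from 2500 nM to 14000 nM, meaning an expected step of a 1.0-fold lower number from compound 3 to compound 4 (0.00 log units; within the scatter).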

Compound 4, half-maximal inhibitory concentration: > 40000 nM
Compound 4: a limit, no number; the forecaster's own chance of this, stated with the estimate: 5%; at least 6.6-fold (0.82 log units) between middle value and limit.
By their numbers in this assay, from the lowest: compounds 3, 1 and 2 (each within the scatter of the next). At a limit, above all of these: compound 4.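

The value of compound 4 in this assay is a limit of the assay and not a number: the limit of > 40000 nM in this assay, at which 1 of the 4 values shown sits. Even so, the amide-type nitrogen in the ring proves not to be indifferent to what it carries, since 3-methoxyphenyl in place of cyclopropyl gives an at least 6.6-fold higher number from compound 3 to compound 4 (0.82 log units; beyond the scatter), in place of hydrogen gives an at least 5.6-fold higher number from compound 2 to compound 4 (0.75 log units; beyond the scatter) and in place of cyclohexyl gives an at least 6.5-fold higher number from compound 1 to compound 4 (0.81 log units; beyond the scatter). The flat picture from hydrogen, cyclopropyl and cyclohexyl therefore does not extend to every group at this position, and a carbon ring as such does not set compound 4 apart, as compound 1 and compound 3 also carry one there; only compound 4 carries an aromatic ring with a methoxy group on it.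

The compounds shown leave open whether plain phenyl, without the methoxy group, would behave like compound 4 or like compound 1, and so which part of 3-methoxyphenyl goes with the weaker result. They also say nothing about groups on this nitrogen that are not rings, such as methyl, a longer chain, or a chain ending in an amine or a carboxylic acid.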